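This account rests on a few compounds, and the source may have more. Where it says the series, first, only, none or still open, it means among the compounds named here.

Three compounds share a common core and differ only in the group carried on an aromatic carbon of a six-membered aromatic ring of carbon only. Compound 1 `Cn1c(=O)c2nc(-c3ccc(Cl)cc3)[nH]c2n(C)c1=O` carries chloro and gives 0.8 nM in an assay for binding affinity to adenosine receptor A1 (Bos taurus); on this read-out higher numbers stand for weaker inhibition and lower numbers for stronger inhibition. Compound 2 `Cc1ccc(-c2nc3c(=O)n(C)c(=O)n(C)c3[nH]2)cc1` carries methyl and gives 0.8 nM in this assay; no change at the digits printed from compound 1 to compound 2 (within the scatter). Compound 3 `Cn1c(=O)c2nc(-c3ccc(F)cc3)[nH]c2n(C)c1=O` carries fluoro and gives 3.5 nM in this assay, the highest of the three numbers, with a 4.4-fold higher number from compound 1 to compound 3 (0.64 log units; beyond the scatter) and a 4.4-fold higher number from compound 2 to compound 3 (0.64 log units; beyond the scatter). Compound 4 `Cn1c(=O)c2nc(-c3ccc([N+](=O)[O-])cc3)[nH]c2n(C)c1=O` differs from compound 3 by nitro in place of fluoro on an aromatic carbon. Within the data shown here, the steps that bear on this change are the two that exchange the group at the same place, from compound 1 to compound 3 and from compound 2 to compound 3, both modest and both raising the number when fluoro enters. Leaving fluoro is therefore expected to lower the number in this assay by a modest amount, a 2.3-fold lower number from compound 3 to compound 4 (0.37 log units; beyond the scatter), though nitro itself has no precedent among these compounds. Compound 4 is estimated at 1.5 nM, within 0.4 nM to 6 nM.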

Compound 4, half-maximal inhibitory concentration: 8 nM
For compound 4 the middle estimate is 5.3-fold (0.73 log units) below the measured one; measured number outside the range, above it.
By their numbers in this assay, from the lowest: compounds 1 and 2 (each within the scatter of the next); then compound 3; then compound 4.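

In this assay the exchange at this aromatic carbon gives a 2.3-fold higher number from compound 3 to compound 4 (0.36 log units; beyond the scatter) and so shows that leaving fluoro does not by itself lower the number, since the group that enters can raise it further. The same group gives a 10-fold higher number from compound 1 to compound 4 (1.00 log units; beyond the scatter) and a 10-fold higher number from compound 2 to compound 4 (1.00 log units; beyond the scatter) and so widens the span among the four groups at this place well beyond what chloro, methyl and fluoro had shown. Nothing available here explains why nitro stands above the other three groups.

On these data alone, with only four groups at this place, it remains open where an amine, a methoxy group or a carboxylic acid would fall in this assay and whether the order of the four follows any simple trend. As far as these compounds go, it is also open whether the same order would hold with these groups elsewhere on the ring.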